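Amide substituent change on the dichlorobenzyl analogue

The source may hold more compounds than are shown below. What is called first, only, known or untested is meant among the compounds shown, and "the series" means these compounds.

Compound 3 `O=C(NC1CCCCC1)C1CCN(Cc2ccc(Cl)cc2Cl)CC1` sits second highest of the three numbers in an assay for displacement of a labelled ligand from Sigma non-opioid intracellular receptor 1 (Cavia porcellus); a lower number here means a stronger inhibitor, a higher number a weaker inhibitor: compound 3 gives 52 nM, compound 1 `O=C(NC1CCCCC1)C1CCN(Cc2ccc(Cl)cc2)CC1` gives 7.7 nM and compound 2 `CC(C)NC(=O)C1CCN(Cc2ccc(Cl)cc2)CC1` gives 637 nM. Compound 4 `CC(C)NC(=O)C1CCN(Cc2ccc(Cl)cc2Cl)CC1` is not yet measured; it differs from compound 3 by isopropyl in place of cyclohexyl on an amide-type nitrogen. Going by the values given here, two measured steps bear on it. The same replacement was seen once, as an 83-fold higher number from compound 1 to compound 2 (1.92 log units; beyond the scatter). The other step, a 6.8-fold higher number from compound 1 to compound 3 (0.83 log units; beyond the scatter), only fixes the starting point of compound 3 relative to compound 1. For compound 4 a large rise in this assay, beyond the scatter, is therefore expected, an 83-fold higher number from compound 3 to compound 4 (1.92 log units; beyond the scatter). Compound 4 is estimated at 4300 nM, in the range 1400 nM to 13000 nM.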

Compound 4, inhibition constant: > 2000 nM
Compound 4 gave a limit, no number; the forecaster's own chance of this, stated with the estimate: 5%; the middle value does not contradict the limit.
By their numbers in this assay, from the lowest: compound 1; then compound 3; then compound 2. At a limit, above all of these: compound 4.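

In this assay compound 4 gives only a limit, > 2000 nM, not a number. Isopropyl in place of cyclohexyl raises the number on a second core, giving an at least 38-fold higher number from compound 3 to compound 4 (1.58 log units; beyond the scatter), and the added chloro also raises it on a second core, giving an at least 3.1-fold higher number from compound 2 to compound 4 (0.49 log units; beyond the scatter). Both changes thus keep their direction on both cores, but their sizes cannot be compared at this limit.

On these data alone, it remains open how far compound 4 lies beyond its limit. As far as these compounds go, it is also open how a cyclopentyl group, a phenyl group or a longer chain such as n-hexyl would behave on the amide-type nitrogen.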